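Swapping a benzyl for a hexyl chain on the ether

This account rests on a few compounds, and the source may have more. Where it says the series, first, only, none or still open, it means among the compounds named here.

Of the compounds shown here, two with a shared core have been measured in an assay for inhibition of Dihydrofolate reductase (Gallus gallus); a lower number here means a stronger inhibitor, a higher number a weaker inhibitor. Compound 1 `Nc1ncc(Cc2ccccc2F)c(N)n1` carries a fluorine on its outer ring, and in this assay compound 1 gives 43700 nM. Compound 2 `Nc1ncc(Cc2ccccc2OCc2ccccc2)c(N)n1` instead carries a benzyl ether at the same outer ring, and in this assay compound 2 gives 9120 nM. On these two numbers compound 2 holds the lower one, and the gap to compound 1 is beyond the usual scatter, so compound 2 is the stronger of the pair. Compound 3 `CCCCCCOc1ccccc1Cc1cnc(N)nc1N` has not yet been measured. The change from compound 2 to compound 3 is pentyl in place of phenyl on a saturated chain carbon bound to an oxygen on an aromatic ring, so the ether now ends in an open chain of carbon rather than in a second ring. Among the compounds with values here, the groups that leave and enter are counted as almost the same size, and nothing among the measured pairs shows what such a swap does. A step from compound 2 to compound 3 within the scatter, in either direction, is therefore expected, as a 1.0-fold lower number from compound 2 to compound 3 (0.01 log units; within the scatter). The value for compound 3 in this assay is estimated at 9000 nM, within a range from 3000 nM to 30000 nM.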

Compound 3, inhibition constant: 7940 nM
Beside the measured number, compound 3's estimate is 1.1-fold (0.05 log units) above it; the measured number falls inside the stated range.
By their numbers in this assay, from the lowest: compounds 3 and 2 (each within the scatter of the next); then compound 1.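

In this assay the change of phenyl to pentyl on the saturated chain carbon bound to an oxygen on an aromatic ring gives a 1.1-fold lower number from compound 2 to compound 3 (0.06 log units; within the scatter) and so leaves the two compounds level, which means that among these compounds a second aromatic ring at the end of the ether is not required to reach this number. The hexyl ether also stands clearly apart from the fluorine compound, with a 5.5-fold lower number from compound 1 to compound 3 (0.74 log units; beyond the scatter) for the change of fluoro to hexyloxy on an aromatic carbon, so an ether ending in an open chain of carbon can also give a number clearly lower than that of compound 1. Nothing at hand explains why a benzyl and a hexyl group on this ether give such closely matching numbers.

Within the data shown here, with only one ring and one open chain at this place, it remains open how the number would respond to a shorter chain such as propyl or a longer chain such as octyl. Going by these compounds, it is also open whether a chain ending in an amine or a carboxylic acid would keep the number at this level.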